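Swapping the anilino end of compound 3 for a bicyclic group

The source may hold more compounds than are shown below. What is called first, only, known or untested is meant among the compounds shown, and "the series" means these compounds.

Compound 1 `CC(C)=CCc1cc(C(=O)Nc2cc3ccc(OCC4CCCN(C)C4)c(C)c3oc2=O)ccc1O` gives 2640 nM in a functional assay on MCF7 cells (Homo sapiens) for antiproliferative activity; a lower number here means a stronger inhibitor, a higher number a weaker inhibitor. Compound 2 `CCN(CC)CCCOc1ccc2cc(NC(=O)c3ccc(O)c(CC=C(C)C)c3)c(=O)oc2c1C` gives 6390 nM, and the step between these two is a 2.4-fold higher number from compound 1 to compound 2 (0.38 log units; beyond the scatter).

Compound 3 `CC(C)=CCc1cc(C(=O)Nc2cc3ccc(OCCCNc4ccccc4)c(C)c3oc2=O)ccc1O` gives > 50000 nM, which is a limit of the assay and not a number. It stands as the weakest of the three.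

Compound 4 `CC(C)=CCc1cc(C(=O)Nc2cc3ccc(OCCCN[C@@H]4C[C@H]5CC[C@@H]4C5)c(C)c3oc2=O)ccc1O` differs from compound 3 by a group of 7 heavy atoms (7 carbon; 2 five-membered non-aromatic rings of carbon only) in place of a group of 6 heavy atoms (6 carbon; one six-membered aromatic ring of carbon only), on an amine nitrogen. The phenyl leaves, and two five-membered non-aromatic rings enter on the same amine nitrogen.

The closest measured change is anilino in place of diethylamino, an at least 7.8-fold higher number from compound 2 to compound 3 (0.89 log units; beyond the scatter). The step with the 1-methylpiperidin-3-yl compound, an at least 18-fold higher number from compound 1 to compound 3 (1.27 log units; beyond the scatter), also ends at compound 3. Within the data shown here, no measured compound carries the entering group, so these steps give only a direction.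

With the phenyl gone, a modest to large move to a lower number in this assay is expected, bringing the value back towards compound 2 at 6390 nM. The expected change is an at least 8.3-fold lower number from compound 3 to compound 4 (0.92 log units; beyond the scatter). Compound 4 is estimated at 6000 nM, with an expected range of 1800 nM to 25000 nM.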

Compound 4, half-maximal inhibitory concentration: 1030 nM
Compound 4: the middle estimate sits 5.8-fold (0.77 log units) above what was measured, outside the stated range (below it).
By their numbers in this assay, from the lowest: compound 4; then compound 1; then compound 2. At a limit, above all of these: compound 3.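

On the amine nitrogen, replacing the phenyl with the group of two five-membered non-aromatic rings recovers activity in this assay, with an at least 48-fold lower number from compound 3 to compound 4 (1.68 log units; beyond the scatter). Compound 3 stands at a limit of the assay and not at a number, so that step is only a bound: the limit of > 50000 nM in this assay, at which 1 of the 4 values shown sits. The same end group also goes past the diethylamino and 1-methylpiperidin-3-yl side chains, with a 6.2-fold lower number from compound 2 to compound 4 (0.79 log units; beyond the scatter) and a 2.6-fold lower number from compound 1 to compound 4 (0.41 log units; beyond the scatter), which shows that a ring-bearing amine nitrogen at this position can give the lowest value of the four.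

As far as these compounds go, whether the two five-membered rings are required remains open, since a simple cyclohexyl or cyclopentyl group on the same nitrogen would test that directly. From the compounds shown here alone, the contribution of the three defined stereocentres is also open, as is whether a benzyl group would behave like the phenyl.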